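From 3,4-difluorophenyl to 4-chlorophenyl on the amide nitrogen

The source may hold more compounds than are shown below. What is called first, only, known or untested is meant among the compounds shown, and "the series" means these compounds.

Measured so far in a functional assay on SEM cells (Homo sapiens) for inhibition, read by MTT assay, with a stated time of 72 h (on this read-out lower numbers stand for stronger inhibition and higher numbers for weaker inhibition), on three compounds:
compound 1 `C=C(Br)C(=O)Nc1cccc(/C=C/C(=O)Nc2ccccc2)c1` gives 1100 nM here
compound 2 `C=C(Br)C(=O)Nc1cccc(/C=C/C(=O)Nc2cccc(F)c2)c1` gives 620 nM here
compound 3 `C=C(Br)C(=O)Nc1cccc(/C=C/C(=O)Nc2ccc(F)c(F)c2)c1` gives 90 nM here

Compound 3 holds the lowest number of the three, and its gaps to both others lie beyond the usual scatter. The next compound, compound 4 `C=C(Br)C(=O)Nc1cccc(/C=C/C(=O)Nc2ccc(Cl)cc2)c1`, keeps the core and alters one group on an amide-type nitrogen: 4-chlorophenyl in place of 3,4-difluorophenyl on an amide-type nitrogen in this swap.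

For the measured compounds named here, three measured steps bear on this. Fluoro in place of hydrogen gave a 1.8-fold lower number from compound 1 to compound 2 (0.25 log units; within the scatter) in one case, which is no real change, but a 6.9-fold lower number from compound 2 to compound 3 (0.84 log units; beyond the scatter) in the other. Taken together, 3,4-difluorophenyl in place of phenyl gave a 12-fold lower number from compound 1 to compound 3 (1.09 log units; beyond the scatter) as a large step. Going by the values given here, no compound with chlorine has been measured, so the effect of this swap remains untested. Compound 4 gives up the 3,4-difluorophenyl group that went with a 12-fold lower number from compound 1 to compound 3 (1.09 log units; beyond the scatter) in the earlier comparison, so part of that gain is expected to disappear. The expected result is a 3.3-fold higher number from compound 3 to compound 4 (0.52 log units; beyond the scatter) as a modest step towards weaker inhibition, though the uncertainty is wide. Compound 4 is expected at 300 nM with 90 nM to 1000 nM as the estimated range.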

Compound 4, half-maximal inhibitory concentration: 1190 nM
For compound 4 the middle estimate is 4.0-fold (0.60 log units) below the measured one; measured number above the stated range.
By their numbers in this assay, from the lowest: compound 3; then compounds 2, 1 and 4 (each within the scatter of the next).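

In this assay, the step at this amide-type nitrogen is large: a 13-fold higher number from compound 3 to compound 4 (1.12 log units; beyond the scatter) shows that the gain seen with the 3,4-difluorophenyl group does not carry over to the 4-chlorophenyl group, even though both are halogen-bearing phenyl groups. Compound 4 also cannot be told apart from the plain phenyl of compound 1, with a 1.1-fold higher number from compound 1 to compound 4 (0.03 log units; within the scatter) within the scatter, or from the 3-fluorophenyl of compound 2, with a 1.9-fold higher number from compound 2 to compound 4 (0.28 log units; within the scatter) also within the scatter, so among these four compounds the single halogen atoms of compound 2 and compound 4 bring no clear gain, and only compound 3 stands apart from all the others. No measurement available here explains why the two halogen-bearing groups in compound 3 and compound 4 differ so sharply.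

The swap from compound 3 to compound 4 changes both the kind of halogen and the number of halogen atoms, and these two changes cannot be separated with the compounds shown. On these data alone, it also remains open whether a group of another kind in place of the chlorine, such as methoxy, trifluoromethyl or a nitrile, would match compound 3 or stay with compound 1, compound 2 and compound 4.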